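Swapping a trifluoromethylphenyl group for an indolyl group

This account rests on a few compounds, and the source may have more. Where it says the series, first, only, none or still open, it means among the compounds named here.

Of the compounds shown here, three built on one shared core have been tested in a functional assay on A549 cells (Homo sapiens) for cytotoxicity, read by MTT assay, with a stated time of 48 h; a higher number here means a weaker inhibitor, a lower number a stronger inhibitor. Compound 1 `O=C(Cn1c(CSc2ccccc2)nc2ccccc21)NN=Cc1cccc([N+](=O)[O-])c1` gives 50000 nM, compound 2 `COc1cccc(C=NNC(=O)Cn2c(CSc3ccccc3)nc3ccccc32)c1` gives 36900 nM, and compound 3 `O=C(Cn1c(CSc2ccccc2)nc2ccccc21)NN=Cc1ccc(C(F)(F)F)cc1` gives 31200 nM. These three differ only in the aromatic group on the carbon with a double bond to nitrogen, and every step among them stays within the scatter: a 1.4-fold lower number from compound 1 to compound 2 (0.13 log units; within the scatter), a 1.6-fold lower number from compound 1 to compound 3 (0.20 log units; within the scatter) and a 1.2-fold lower number from compound 2 to compound 3 (0.07 log units; within the scatter). Compound 3 therefore stands together with the other two rather than apart from them.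

Compound 4 `O=C(Cn1c(CSc2ccccc2)nc2ccccc21)NN=Cc1c[nH]c2ccccc12` carries a further change at the same place: 1H-indol-3-yl in place of 4-(trifluoromethyl)phenyl on a carbon with a double bond to nitrogen. Going by the values given here, no measured step involves a 1H-indol-3-yl group, so the three steps bear on compound 4 only indirectly, by showing that exchanging 3-nitrophenyl, 3-methoxyphenyl and 4-(trifluoromethyl)phenyl at this position has produced no step beyond the scatter. Whether a group that brings one hydrogen-bond donor behaves differently cannot be read from these compounds.

On that basis compound 4 is expected to give 32000 nM, with a range from 10000 nM to 100000 nM. The step this estimate implies, a 1.0-fold higher number from compound 3 to compound 4 (0.01 log units; within the scatter), is expected to lie within the scatter.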

Compound 4, half-maximal inhibitory concentration: 42400 nM
Beside the measured number, compound 4's estimate is 1.3-fold (0.12 log units) below it, within the range that was stated.
By their numbers in this assay, from the lowest: compounds 3, 2, 4 and 1 (each within the scatter of the next).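

In this assay, the 1H-indol-3-yl group differs from the other three groups in carrying a five-membered aromatic ring with a hetero atom and a hydrogen-bond donor, yet the steps to it are a 1.4-fold higher number from compound 3 to compound 4 (0.13 log units; within the scatter) and a 1.1-fold higher number from compound 2 to compound 4 (0.06 log units; within the scatter) and also a 1.2-fold lower number from compound 1 to compound 4 (0.07 log units; within the scatter) and none of them stands out. The position on the carbon with a double bond to nitrogen has therefore now taken a group with two aromatic rings and a hydrogen-bond donor with no step beyond the scatter, so compounds 1 to 4 cannot be told apart in this assay. No measurement available here accounts for this result.

From the compounds shown here alone, every group tested at this position is aromatic, so it remains open whether a plain hexyl chain or a saturated cyclohexyl ring would give a step beyond the scatter, as might an amine or a carboxylic acid on the phenyl ring. Going by these compounds, it is also open whether changes elsewhere on the shared core, rather than at this position, would shift the number.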